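Salicylanilide series: halogen swap at the phenol ring

The source may hold more compounds than are shown below. What is called first, only, known or untested is meant among the compounds shown, and "the series" means these compounds.

Measured compounds:
compound 1 `N#Cc1ccc(NC(=O)c2cc(F)ccc2O)cc1` — 1420 nM
compound 2 `O=C(Nc1ccccc1)c1cc(F)ccc1O` — > 10000 nM

Notes. In a functional assay on HL-60 cells (Homo sapiens) for cytotoxicity, read by luminescence and CellTiter-Glo, with a stated time of 3 days (on this read-out higher numbers stand for weaker inhibition and lower numbers for stronger inhibition), compound 1 gives 1420 nM. For the measured compounds named here, of the two measured compounds, compound 1 is the only one with a definite number. For compound 2 the result in this assay is a limit, > 10000 nM, not a number. Going by the values given here, the one measured step, an at least 7.0-fold higher number from compound 1 to compound 2 (0.84 log units; beyond the scatter), rests on this limit, (the limit of > 10000 nM in this assay, at which 1 of the 2 values shown sits), so its true size is unknown beyond its stated floor.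

Compound 3 `N#Cc1ccc(NC(=O)c2cc(Br)ccc2O)cc1` is not yet measured. It differs from compound 1 as follows: bromo in place of fluoro on an aromatic carbon. The cyano group, which the measured step concerns, is unchanged in compound 3. Among the compounds with values here, no measured step touches the halogen on the shared core, so there is nothing in the data to tell how large or in which direction the step to compound 3 runs.

Absent any measured halogen step, no change beyond the scatter is expected from the bromo in place of fluoro, and the estimated step is a 1.2-fold lower number from compound 1 to compound 3 (0.07 log units; within the scatter). Compound 3 is therefore estimated at 1200 nM, within a range of 400 nM to 4000 nM.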

Compound 3, half-maximal inhibitory concentration: 620 nM
The estimate for compound 3 lay 1.9-fold (0.29 log units) above the measured number; the range from low to high includes it.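

Bromo in place of fluoro gives a 2.3-fold lower number from compound 1 to compound 3 (0.36 log units; beyond the scatter) in this assay, so the halogen on the shared core is not a silent position in this series. For the compounds shown here, until now the only measured step concerned the cyano group; this place, para to a hydroxy group and meta to a large group, now also moves the number beyond the scatter while the cyano group stays unchanged. Nothing measured here accounts for why bromo and fluoro differ at this place.

The compounds shown leave open whether chloro or iodo would fall with fluoro or with bromo, whether an amine or a methyl group at the same place would keep the number, and whether the bromo step carries over to a compound without the cyano group. Going by these compounds alone, for that last comparison the only reference is compound 2, whose result in this assay is a limit, > 10000 nM, and not a number.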